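The source may report more compounds than this note shows. Statements on the series, on what has been measured and on what is new or still open speak of the compounds shown alone.

Measured compounds in a functional assay on HEK293 cells for agonist activity at Glucose-dependent insulinotropic receptor (Homo sapiens), read by cAMP accumulation, with a stated time of 30 min; on this read-out higher numbers stand for an effect only at larger amounts of compound and lower numbers for an effect already at smaller amounts:
compound 1 `CC(C)OC(=O)N1CCC(n2ncc3cc(-c4ccc(S(C)(=O)=O)cc4)ncc32)CC1`: 42 nM
compound 2 `CC(C)(C)OC(=O)N1CCC(n2ncc3cc(-c4ccc(S(C)(=O)=O)cc4)ccc32)CC1`: 31 nM
compound 3 `CC(C)COC(=O)N1CCC(n2ncc3cc(-c4ccc(S(C)(=O)=O)cc4)ncc32)CC1`: 11 nM

Compound 3 stands at the lowest of the three numbers in this assay. Compound 2 is nearest, its number higher by an amount beyond the scatter; compound 1 is furthest, also beyond the scatter. Within the data shown here, the one single-point step available is a 3.8-fold lower number from compound 1 to compound 3 (0.58 log units; beyond the scatter); it exchanges the chain on the oxygen of the carbamate and leaves the carbamate itself in place.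

Compound 4 `CC(C)CCN1CCC(n2ncc3cc(-c4ccc(S(C)(=O)=O)cc4)ncc32)CC1` differs from compound 3 as follows: isopentyl in place of isobutoxycarbonyl on an amine nitrogen in a ring. Among the measured compounds shown here, all three measured compounds carry a carbamate on that ring nitrogen, so no measured step removes the carbonyl and the oxygen or replaces them by a plain chain. The step of a 3.8-fold lower number from compound 1 to compound 3 (0.58 log units; beyond the scatter) touches only the far end of that group and does not bear directly on this change. With the carbamate gone in compound 4, the expectation is a step of a 14-fold higher number from compound 3 to compound 4 (1.13 log units; beyond the scatter) toward a higher number in this assay, held with wide uncertainty. Compound 4 is estimated at 150 nM, with a range from 30 nM to 800 nM.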

Compound 4, half-maximal effective concentration: 220 nM
Compound 4: the middle estimate sits 1.5-fold (0.17 log units) below what was measured, within the range that was stated.
By their numbers in this assay, from the lowest: compound 3; then compounds 2 and 1 (each within the scatter of the next); then compound 4.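

In this assay, among these compounds, this is the first view of the amine nitrogen in a ring carrying something other than a carbamate: isopentyl in place of isobutoxycarbonyl gives a 20-fold higher number from compound 3 to compound 4 (1.30 log units; beyond the scatter) and the step is large, so a plain chain of this kind does not stand in for that group here. Read against the shorter-branched carbamate, the same kind of exchange gives a 5.2-fold higher number from compound 1 to compound 4 (0.72 log units; beyond the scatter) and is modest but still beyond the scatter, so both carbamates that can be compared in one place stand at lower numbers than compound 4, and the direction does not depend on which of the two is taken as the start. No accompanying measurement bears on why the number rises at this position.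

On these data alone, whether the carbonyl or the oxygen of the carbamate carries the difference stays open, since an amide or a urea on the amine nitrogen in a ring would separate the two. Also open, as far as these compounds go, is how a shorter or longer alkyl chain, or a sulfonamide, on that nitrogen would sit relative to isopentyl.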